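Cytotoxicity on adding a second trifluoromethyl group

The source may hold more compounds than are shown below. What is called first, only, known or untested is meant among the compounds shown, and "the series" means these compounds.

Measured in an ADME assay on RAW264.7 cells (Mus musculus) for cytotoxicity, read by MTT assay, with a stated time of 48 h; on this read-out lower numbers stand for stronger inhibition and higher numbers for weaker inhibition:
compound 1 `COc1cc(NC(=O)c2cc(C(F)(F)F)cc(C(F)(F)F)c2)ccc1NS(C)(=O)=O` gives > 250000 nM, a limit of the assay.
compound 2 `CCS(=O)(=O)Nc1ccc(NC(=O)c2cccc(C(F)(F)F)c2)cc1OC` gives 84800 nM.

Compound 2 holds the only number shown in this assay. The other value is the limit of > 250000 nM in this assay, at which 1 of the 2 values shown sits. Compound 3 `CCS(=O)(=O)Nc1ccc(NC(=O)c2cc(C(F)(F)F)cc(C(F)(F)F)c2)cc1OC` is not yet measured and differs from compound 2 by trifluoromethyl in place of hydrogen on an aromatic carbon. For the measured compounds named here, no measured pair shares this change, so no step size is known. Compound 1 also carries two trifluoromethyl groups and gives > 250000 nM, a limit. The expected step in this assay is towards weaker inhibition, a higher number, perhaps again only a limit: a 2.4-fold higher number from compound 2 to compound 3 (0.37 log units; beyond the scatter). Compound 3 is estimated at 200000 nM, with a range from 60000 nM to 600000 nM.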

Compound 3, half-maximal inhibitory concentration: > 250000 nM
Compound 3: a limit, no number (the forecaster's own chance of this, stated with the estimate: 50%); middle value at least 1.2-fold (0.09 log units) away from the limit.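

In this assay, for the compounds shown here, trifluoromethyl in place of hydrogen on this aromatic carbon, meta to a trifluoromethyl group, gives the first readable step for this change: an at least 2.9-fold higher number from compound 2 to compound 3 (0.46 log units; beyond the scatter). On these data alone, compound 3 gives > 250000 nM, a limit and not a number, so the full size of the step stays unknown. The step between compound 1 and compound 3 cannot be read, and both sit at the same limit: the limit of > 250000 nM in this assay, at which 2 of the 3 values shown sit.

As far as these compounds go, whether an amine or a nitrile at this place would give a number below the limit remains open. So does the effect of a longer chain on the sulfonyl sulfur.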